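This account rests on a few compounds, and the source may have more. Where it says the series, first, only, none or still open, it means among the compounds named here.

Working notes on the series. In an ADME assay on HEK-293T cells (Homo sapiens) for cytotoxicity, read by MTT assay, with a stated time of 24 h (on this read-out lower numbers stand for higher toxicity in this test and higher numbers for lower toxicity in this test), compound 1 (`O=S(=O)(c1ccc(Br)cc1)n1c(-c2cn(-c3ccccc3)nc2-c2ccc(F)cc2)nc2ccccc21`) gives 239000 nM and compound 2 (`O=[N+]([O-])c1ccc(S(=O)(=O)n2c(-c3cn(-c4ccccc4)nc3-c3ccc(C(F)(F)F)cc3)nc3ccccc32)cc1`) gives 163000 nM on the same read-out. These two numbers lie within the usual scatter of each other, so compound 2 cannot be separated from compound 1 and the pair gives no ranking. Both sit in the same broad region of the scale.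

The next compound is compound 3 (`O=S(=O)(c1ccc(Br)cc1)n1c(-c2cn(-c3ccccc3)nc2-c2ccc(C(F)(F)F)cc2)nc2ccccc21`), with the change from compound 2 counted as bromo in place of nitro on an aromatic carbon in the notes. In words, it is bromo in place of nitro on an aromatic carbon, para to a large group. Within the data shown here, no two measured compounds differ in one place, so the data hold no direct reading for this swap. With so little to go on, no step beyond the scatter is expected in this assay and no direction is favoured. The expected change is a 1.2-fold higher number from compound 2 to compound 3 (0.08 log units; within the scatter) as an estimate, which stays within the scatter. The estimated value for compound 3 is 195000 nM with an expected range of 100000 nM to 380000 nM for repeated measurements.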

Compound 3, half-maximal cytotoxic concentration: 185000 nM
Compound 3: middle estimate off by 1.1-fold (0.02 log units), on the high side, and the stated range covers the measured number.
By their numbers in this assay, from the lowest: compounds 2, 3 and 1 (each within the scatter of the next).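

In this assay, 4-bromophenyl in place of 4-nitrophenyl on the sulfonyl gives a 1.1-fold higher number from compound 2 to compound 3 (0.05 log units; within the scatter), so this swap on an aromatic carbon, para to a large group, cannot be told apart from no change. Compound 3 also links compound 1 and compound 2, which differ in two places, and so gives a second single-place reading: trifluoromethyl in place of fluoro on an aromatic carbon gives a 1.3-fold lower number from compound 1 to compound 3 (0.11 log units; within the scatter), and this swap too cannot be separated from no change. Neither reading comes with any measurement that would point to a cause.

Going by these compounds, whether this position can move the number beyond the scatter at all remains open for groups such as an amine or a carboxylic acid in place of bromo on the same six-membered aromatic ring. The same question stands for a methoxy group or a longer chain in place of trifluoromethyl, and the three compounds together speak for one cell line and one stated time only.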